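The compounds below may be only part of what the source reports. "The series", "measured", "known", "first", "only" and "open" are said of these compounds alone.

Compound 1 `COC[C@H](C1CC1)n1cc(Cl)nc(Nc2cc(C)c(OC)nc2C)c1=O`: 1.5 nM
Compound 2 `COC[C@@H](C1CC1)n1cc(Cl)nc(Nc2cc(C)c(OC)nc2C)c1=O`: 1.1 nM

In an assay on frontal cortex for displacement of a labelled ligand from corticotropin-releasing factor receptor 1 (Rattus norvegicus) (on this read-out lower numbers stand for stronger inhibition and higher numbers for weaker inhibition), compound 2 gives 1.1 nM, the lower of the two numbers shown, while compound 1 sits within the scatter of it, as a 1.4-fold lower number from compound 1 to compound 2 (0.13 log units; within the scatter) shows, a step that rests on (the fact that compounds 1 and 2 differ only in the configuration as drawn). Compound 3 `CC[C@H](C1CC1)n1cc(Cl)nc(Nc2cc(C)c(OC)nc2C)c1=O` differs from compound 2 in one place: 1-cyclopropylpropyl in place of 1-cyclopropyl-2-methoxyethyl on an aromatic nitrogen. No measured step touches this kind of change; the only step shown concerns configuration, so the direction is open. A modest step in either direction is expected, estimated as a 1.8-fold higher number from compound 2 to compound 3 (0.26 log units; within the scatter). For compound 3 the expected result in this assay is 2 nM, with a likely range from 0.5 nM to 8 nM.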

Compound 3, half-maximal inhibitory concentration: 0.28 nM
Estimate against measurement, compound 3: 7.1-fold (0.85 log units) above; measured number below the stated range.
By their numbers in this assay, from the lowest: compound 3; then compounds 2 and 1 (each within the scatter of the next).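

Exchanging the methoxy end of the side chain for methyl does not weaken inhibition in this assay: the number falls with a 3.9-fold lower number from compound 2 to compound 3 (0.59 log units; beyond the scatter) and with a 5.4-fold lower number from compound 1 to compound 3 (0.73 log units; beyond the scatter). So the oxygen of 1-cyclopropyl-2-methoxyethyl is not needed for strong inhibition here, and compound 3 stands beyond the scatter of both earlier compounds. Nothing shown explains why this change lowers the number.

Still open, from the compounds shown here alone, is whether a longer chain, such as 1-cyclopropylbutyl, or an amine on this chain would lower it further. The mirror-image form of compound 3 also remains an open question.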